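Hydroxy Placement and Cytotoxicity in Dibromopyrrole Chalcones

The compounds below may be only part of what the source reports. "The series", "measured", "known", "first", "only" and "open" are said of these compounds alone.

Measured compounds:
Compound 1, `Cn1c(/C=C/C(=O)c2cccc(O)c2)cc(Br)c1Br`, >= 100000 nM
Compound 2, `Cn1c(/C=C/C(=O)c2ccc(O)cc2O)cc(Br)c1Br`, 180 nM
Compound 3, `Cn1c(/C=C/C(=O)c2ccc(O)cc2)cc(Br)c1Br`, 1910 nM

Three compounds share a core and differ in where hydroxy groups sit on the phenyl ring. In a functional assay on WRL68 cells (Homo sapiens) for cytotoxicity, read by MTT assay, with stated times of 6 h and 48 h (on this read-out higher numbers stand for weaker inhibition and lower numbers for stronger inhibition), compound 1 gives only a limit, >= 100000 nM. Compound 1 stands at the limit of >= 100000 nM in this assay, at which 1 of the 3 values shown sits. Compound 3 gives 1910 nM in this assay, and compound 2 gives 180 nM.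

From compound 3 to compound 2 the change is hydroxy in place of hydrogen on an aromatic carbon. This gives an 11-fold lower number from compound 3 to compound 2 (1.03 log units; beyond the scatter).

Compound 4, `Cn1c(/C=C/C(=O)c2cc(O)ccc2O)cc(Br)c1Br`, has not yet been measured in this assay. From compound 1 to compound 4 the change is hydroxy in place of hydrogen on an aromatic carbon. It is the same kind of change as that from compound 3 to compound 2, but not the same: in one case the new hydroxy is meta to a hydroxy group, in the other it is para to a hydroxy group. How the core of compound 1 differs from that of compound 3 is not broken down here.

For compound 4 the value is expected to be about 12000 nM. The range expected for compound 4 runs from 2500 nM to 100000 nM. The step expected is an at least 8.3-fold lower number from compound 1 to compound 4 (0.92 log units; beyond the scatter). On these data alone, this rests on the measured step of an 11-fold lower number from compound 3 to compound 2 (1.03 log units; beyond the scatter) and on compound 1 giving only a limit, so the true starting point is unknown and the expected number stays high and uncertain.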

Compound 4, half-maximal inhibitory concentration: 880 nM
Compound 4: middle estimate off by 14-fold (1.13 log units), on the high side, and the stated range ends above it.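

Putting a hydroxy in place of hydrogen on an aromatic carbon, here ortho to a large group and para to a hydroxy group, gives an at least 110-fold lower number from compound 1 to compound 4 (2.05 log units; beyond the scatter) in this assay. The direction of the change carries over from one core to the other, but its size does not: the same change on two cores in this assay, an 11-fold lower number (1.03 log units; beyond the scatter) from compound 3 to compound 2 and an at least 110-fold lower number (2.05 log units; beyond the scatter) from compound 1 to compound 4, at least 10-fold (1.02 log units) apart, beyond the scatter of two such steps. Compound 1 is held at a limit and not a number, so the gap between the steps is only a minimum, and two pairs neither make a rule for the series nor say why the sizes differ: the limit of >= 100000 nM in this assay, at which 1 of the 4 values shown sits.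

On these data alone, every substituent that varies on the six-membered aromatic ring here is a hydroxy group, so it stays open whether a methoxy group, an amine or a carboxylic acid in the same places would give steps of similar size. For the compounds shown here, it is also open whether the large difference between the two cores would appear with a further hydroxy arrangement, since only two pairs can be compared so far, and one of them starts from a limit.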